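The source may hold more compounds than are shown below. What is called first, only, known or untested is meant among the compounds shown, and "the series" means these compounds.

Measured compounds:
- Compound 1 `O=C(NOCc1ccc(Cl)cc1Cl)c1cn(-c2ccccc2)nc1-c1ccc(Cl)cc1`: 46300 nM
- Compound 2 `O=C(NOCc1ccccc1Cl)c1cn(-c2ccccc2)nc1-c1ccc(F)cc1`: 44700 nM

Both compounds were tested in an ADME assay on HEK-293T cells (Homo sapiens) for antiproliferative activity, read by MTT assay, with a stated time of 48 h, in the presence of a further agent that is not named here; a higher number here means that more compound is tolerated, a lower number that less compound is tolerated. In this assay compound 1 gives 46300 nM, and in this assay compound 2 gives 44700 nM. Only these two numbers are known, and the gap between them is smaller than the usual scatter of such measurements, so the two compounds cannot be told apart on these data; compound 2 simply stands alongside compound 1.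

The next compound, compound 3 `O=C(NOCc1ccc(Cl)cc1Cl)c1cn(-c2ccccc2)nc1-c1ccc(F)cc1`, has not yet been measured. It differs from compound 2 in one place: chloro in place of hydrogen on an aromatic carbon. The resulting 2,4-dichlorobenzyl group is the same one that compound 1 carries, and compound 1 and compound 2 sit together within the scatter. For the measured compounds named here, no step between measured compounds is available to size this change directly. The expectation for compound 3 is therefore a step of a 1.0-fold higher number from compound 2 to compound 3 (0.00 log units; within the scatter) in this assay, none beyond the scatter. Compound 3 is estimated at 45000 nM, with a range from 25000 nM to 80000 nM.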

Compound 3, half-maximal cytotoxic concentration: 45000 nM
Estimate against measurement, compound 3: no gap at the digits printed; the range from low to high includes it.
By their numbers in this assay, from the lowest: compounds 2, 3 and 1 (each within the scatter of the next).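

In this assay, the step that adds chloro and turns the 2-chlorobenzyl group into the 2,4-dichlorobenzyl group reads a 1.0-fold higher number from compound 2 to compound 3 (0.00 log units; within the scatter), so a second chloro at this place, meta to a chloro group and para to a large group, does not separate the two compounds. The change at a different place in the molecule, fluoro in place of chloro on an aromatic carbon, reads a 1.0-fold lower number from compound 1 to compound 3 (0.01 log units; within the scatter), so it does not separate its two compounds either, and neither single change shifts the number beyond the scatter. No measurement shown here offers any explanation for these two results.

Hydrogen and chloro are the only groups shown at this place on the benzyl ring, so it remains open whether a methoxy group or an amine there would move the number beyond the scatter in this assay. From the compounds shown here alone, it is equally open whether a carboxylic acid in place of the fluoro or chloro at the other place would do so, or whether a longer chain in place of the benzyl group would.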